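A few compounds are considered here, and "the series" means these few. Any claim that something is new, unique, unknown or untested is made for them only; others in the source may bear on it.

Compound 1 `COC(=O)c1c[nH]c2cc(OCCOc3ccccc3)ccc2c1=O` is the reference point here. In an ADME assay on J774 cells (Mus musculus) for cytotoxicity (on this read-out lower numbers stand for an effect already at smaller amounts and higher numbers for an effect only at larger amounts of compound), compound 1 gives > 20000 nM, which is a limit and not a number. Compound 2 `COC(=O)c1c[nH]c2cc(OCCOc3ccccc3)c(C)cc2c1=O` gives > 20000 nM in this assay, which is also a limit. The pair shares that ceiling: the limit of > 20000 nM in this assay, at which 2 of the 2 values shown sit. Compound 3 `COC(=O)c1c[nH]c2cc(OCCc3ccccc3)ccc2c1=O` departs from compound 1 in the side chain, with phenyl in place of phenoxy on a saturated chain carbon, two bonds along the chain from an oxygen on an aromatic ring. For the measured compounds named here, compound 2 supplies the only measured step, a step that the two limits leave unreadable from compound 1 to compound 2, for methyl in place of hydrogen on an aromatic carbon, so no size carries over and no shift beyond the scatter, in either direction, is expected in this assay. The estimated step is a number no higher from compound 1 to compound 3 (the limit leaves the size open). Compound 3 is expected at 20000 nM, with an estimated range of 8000 nM to 40000 nM.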

Compound 3, half-maximal effective concentration: 17200 nM
Beside the measured number, compound 3's estimate is 1.2-fold (0.07 log units) above it; measured number inside the range.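

For the compounds shown here, compound 3 is the first of the three compounds to give a number and not a limit in this assay, so this place, on a saturated chain carbon, two bonds along the chain from an oxygen on an aromatic ring, now has a readable value. Phenyl in place of phenoxy gives an at least 1.1-fold lower number from compound 1 to compound 3 (0.06 log units; that floor lies within the scatter), so only a floor is known for this change, and no shift beyond the scatter is established. The true size of this step stays open, and the step to compound 2 cannot be read, because both earlier compounds sit at one ceiling: the limit of > 20000 nM in this assay, at which 2 of the 3 values shown sit.

As far as these compounds go, what an amine or a carboxylic acid in place of phenyl would do in this assay remains open. So does the effect of a longer chain carrying the phenyl.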